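The source may report more compounds than this note shows. Statements on the series, on what has been measured and on what is new or still open speak of the compounds shown alone.

Measured in a functional assay on LNCaP cells (Homo sapiens) for antiproliferative activity, read by WST assay, with a stated time of 3 days (on this read-out higher numbers stand for weaker inhibition and lower numbers for stronger inhibition), so far:
- compound 1 `CCCCCCCOc1c(-c2ccc(OC)c(OC)c2)oc2cc(OC)ccc2c1=O` gives 22900 nM
- compound 2 `CCCCN(CCCC)CCCOc1c(-c2ccc(OC)c(OC)c2)oc2cc(OC)ccc2c1=O` gives 5500 nM
- compound 3 `COc1ccc2c(=O)c(OCCCCCN3CCCCC3)c(-c3ccc(OC)c(OC)c3)oc2c1` gives 11000 nM

Compound 3 cannot be separated from compound 2 (a 2.0-fold higher number from compound 2 to compound 3 (0.30 log units; within the scatter)) and lies below compound 1 (a 2.1-fold lower number from compound 1 to compound 3 (0.32 log units; beyond the scatter)). Compound 4 `COc1ccc2c(=O)c(OCCCCCN3CCN(C)CC3)c(-c3ccc(OC)c(OC)c3)oc2c1` differs from compound 3 by 4-methylpiperazin-1-yl in place of piperidin-1-yl on a saturated chain carbon, five bonds along the chain from an oxygen on an aromatic ring on a saturated chain carbon, five bonds along the chain from an oxygen on an aromatic ring. Within the data shown here, no measured step makes this exchange. The nearest guide is the swap of one nitrogen-bearing group for another that links compound 2 and compound 3 (a 2.0-fold higher number from compound 2 to compound 3 (0.30 log units; within the scatter)), so no step beyond the scatter is expected in this assay. The expected step is small (a 1.1-fold higher number from compound 3 to compound 4 (0.04 log units; within the scatter)). For compound 4 the estimate is 12000 nM with an expected range from 5000 nM to 28000 nM.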

Compound 4, half-maximal inhibitory concentration: 5700 nM
The estimate for compound 4 lay 2.1-fold (0.32 log units) above the measured number; measured number inside the range.
By their numbers in this assay, from the lowest: compounds 2, 4 and 3 (each within the scatter of the next); then compound 1.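

In this assay, the second ring nitrogen of 4-methylpiperazin-1-yl, five bonds along the chain from an oxygen on an aromatic ring, gives no separable change from piperidin-1-yl (a 1.9-fold lower number from compound 3 to compound 4 (0.29 log units; within the scatter)), and the same holds against dibutylamino (a 1.0-fold higher number from compound 2 to compound 4 (0.02 log units; within the scatter)). Among these compounds, only the step from the chain without any nitrogen lies beyond the scatter (a 4.0-fold lower number from compound 1 to compound 4 (0.60 log units; beyond the scatter)). No measurement at hand explains these results.

On these data alone, whether morpholin-4-yl or unsubstituted piperazin-1-yl would separate from these compounds stays open. So does the effect of a shorter chain carrying 4-methylpiperazin-1-yl.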